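The source may hold more compounds than are shown below. What is called first, only, known or untested is meant among the compounds shown, and "the series" means these compounds.

Working notes on the series. Compound 1 `Cc1ccc(C(=O)Nc2nc(Cl)c3cn(C)nc3n2)cc1` carries an amide on the shared core; in an assay on CHO cells for displacement of a labelled ligand from adenosine receptor A3 (Homo sapiens), read by scintillation counting, with a stated time of 3 h (a lower number here means a stronger inhibitor, a higher number a weaker inhibitor), compound 1 gives 13500 nM. Compound 2 `CC(C)(C)Cn1cc2c(Cl)nc(N)nc2n1` carries a free amine and a longer chain on the ring nitrogen. In this assay compound 2 gives > 60000 nM, which is a limit of the assay and not a number. Compound 3 `Cn1cc2c(Cl)nc(N)nc2n1` keeps the free amine with a methyl on the ring nitrogen. In this assay compound 3 gives > 100000 nM, again a limit rather than a number. Compound 3 therefore stands at a limit, and of the three values shown one further is also a limit. Among the compounds with values here, the only step at this position, a step that the two limits leave unreadable from compound 2 to compound 3, cannot be sized, since both ends sit at limits: the limit of > 60000 nM in this assay, at which 1 of the 3 values shown sits, for compound 2, and the limit of > 100000 nM in this assay, at which 1 of the 3 values shown sits, for compound 3.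

Compound 4 `CC(C)n1cc2c(Cl)nc(N)nc2n1` is not yet measured. It differs from compound 3 by isopropyl in place of methyl on an aromatic nitrogen. Within the data shown here, the one step that bears on this change is the unreadable one from compound 2 to compound 3, so no size can be read for a chain change at this nitrogen, and no movement beyond the scatter is predicted in either direction. The expectation for compound 4 in this assay is 80000 nM (range 20000 nM to 250000 nM), and the step from compound 3 is expected as an at least 1.2-fold lower number from compound 3 to compound 4 (0.09 log units; that floor lies within the scatter), most likely reported as a limit again.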

Compound 4, inhibition constant: > 100000 nM
Compound 4: a limit, no number (the forecaster's own chance of this, stated with the estimate: 75%); middle value at least 1.2-fold (0.09 log units) from the limit.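

In this assay compound 4 gives > 100000 nM, a limit of the assay and not a number. The steps among compound 2, compound 3 and compound 4 therefore cannot be read. The compounds shown leave open whether any chain on the aromatic nitrogen moves the number while the free amine is kept.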